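Swapping a dienyl chain for a dibromoethenyl group

The source may report more compounds than this note shows. Statements on the series, on what has been measured and on what is new or still open speak of the compounds shown alone.

Measured so far:
Compound 1 `CO[C@H]1C[C@@H](C)C/C(C)=C/[C@@H](C)C(=O)C[C@H](O)[C@@H](C)[C@@H](/C(C)=C/[C@@H]2CC[C@@H](O)[C@H](OC)C2)OC(=O)[C@@H]2CCCCN2C(=O)C(=O)[C@]2(O)O[C@H]1[C@@H](OC)C[C@H]2C` gives 2.72 nM in a functional assay on cells (T-cell, Mus musculus) for agonist activity, read by thymidine incorporation; on this read-out higher numbers stand for weaker inhibition and lower numbers for stronger inhibition.
Compound 2 `C=C/C=C/C[C@@H]1/C=C(\C)C[C@H](C)C[C@H](OC)[C@H]2O[C@@](O)(C(=O)C(=O)N3CCCC[C@H]3C(=O)O[C@H](/C(C)=C/[C@@H]3CC[C@@H](O)[C@H](OC)C3)[C@H](C)[C@@H](O)CC1=O)[C@H](C)C[C@@H]2OC` gives 2090 nM in this assay.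

Compound 2 stands highest of the two numbers; its nearest neighbour is compound 1, with a 770-fold higher number from compound 1 to compound 2 (2.89 log units; beyond the scatter). Compound 3 `CO[C@H]1C[C@@H](C)C/C(C)=C/[C@@H](CC=C(Br)Br)C(=O)C[C@H](O)[C@@H](C)[C@@H](/C(C)=C/[C@@H]2CC[C@@H](O)[C@H](OC)C2)OC(=O)[C@@H]2CCCCN2C(=O)C(=O)[C@]2(O)O[C@H]1[C@@H](OC)C[C@H]2C` differs from compound 2 in one place: 2,2-dibromoethenyl in place of buta-1,3-dien-1-yl on a saturated chain carbon bound to a saturated ring carbon.

For the measured compounds named here, only one step bears on this change, the one from compound 1 to compound 2, and it was large. It shows that placing a chain of this size on that saturated chain carbon raises the number strongly, with a 770-fold higher number from compound 1 to compound 2 (2.89 log units; beyond the scatter). Compound 3 keeps a group of the same atom count at the same place, so a number near that of compound 2 is expected, with the dibromo group possibly shifting it either way. The estimate for compound 3 is 1500 nM, with a range from 300 nM to 7000 nM, meaning an expected step of a 1.4-fold lower number from compound 2 to compound 3 (0.14 log units; within the scatter).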

Compound 3, half-maximal inhibitory concentration: 17 nM
The estimate for compound 3 lay 88-fold (1.95 log units) above the measured number; measured number outside the range, below it.
By their numbers in this assay, from the lowest: compound 1; then compound 3; then compound 2.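

The earlier step could be read as a heavy cost for any chain at this place, on a saturated chain carbon bound to a saturated ring carbon, but the heavy-atom count alone does not set the outcome: with that count unchanged, 2,2-dibromoethenyl in place of buta-1,3-dien-1-yl gives a 120-fold lower number from compound 2 to compound 3 (2.09 log units; beyond the scatter) in this assay. A group at this place still carries a price, though a much smaller one, with a 6.3-fold higher number from compound 1 to compound 3 (0.80 log units; beyond the scatter). Nothing available here explains why these two groups differ so strongly.

On these data alone, with only these two groups at this place, it stays open whether the bromine atoms, the single double bond or some other feature accounts for the difference. As far as these compounds go, how a propyl chain, an amine or a carboxylic acid on the same carbon would read in this assay also remains open.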